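The source may report more compounds than this note shows. Statements on the series, on what has been measured and on what is new or still open speak of the compounds shown alone.

In a functional assay on MDA-MB-468 cells (Homo sapiens) for cytotoxicity, read by MTT assay, with a stated time of 72 h (on this read-out lower numbers stand for stronger inhibition of growth and higher numbers for weaker inhibition of growth), compound 1 `COc1ccc(CS(=O)(=O)/C=C/c2ccc(OC)c(OC)c2OC)cc1[N+](=O)[O-]` gives 21900 nM, and compound 2 `COc1ccc(CS(=O)(=O)/C=C/c2ccc(OC)c(OC)c2OC)cc1N` gives 3480 nM. The change between them is amino in place of nitro on an aromatic carbon, and it made a 6.3-fold lower number from compound 1 to compound 2 (0.80 log units; beyond the scatter). Compound 3 `COc1ccc(CS(=O)(=O)CC(=O)Nc2ccccc2)cc1[N+](=O)[O-]` carries the same nitro substituent as compound 1 on a different core; the difference between the two cores is not broken down here. In this assay compound 3 reaches only a limit, reported as > 30000 nM, which is the limit of > 30000 nM in this assay, at which 1 of the 3 values shown sits. Compound 4 `COc1ccc(CS(=O)(=O)CC(=O)Nc2ccccc2)cc1N` has not yet been measured; it differs from compound 3 by amino in place of nitro on an aromatic carbon, the same change as that between compound 1 and compound 2. Resting on that earlier step, and on the limit of compound 3 in this assay, the expected step is an at least 2.5-fold lower number from compound 3 to compound 4 (0.39 log units; beyond the scatter). For compound 4 in this assay a value of 12000 nM is estimated, expected to lie between 3000 nM and 40000 nM.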

Compound 4, concentration for 50% growth inhibition: > 30000 nM
Compound 4: only a limit was reported; the forecaster's own chance of this, stated with the estimate: 35%; middle value at least 2.5-fold (0.39 log units) away from the limit.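

Compound 3 and compound 4 both reach only a limit in this assay, and the step between them cannot be read. On these data alone, whether amino in place of nitro changes the number on the core of compound 3, as it did on the core of compound 1, stays open.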